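Working notes on a cytotoxicity series

A few compounds are considered here, and "the series" means these few. Any claim that something is new, unique, unknown or untested is made for them only; others in the source may bear on it.

Measured compounds:
compound 1 `COc1cc(/C=C/C(=O)Nc2cc3c(Nc4ccc(F)c(Cl)c4)ncnc3cc2OC)cc(OC)c1` — in a functional assay on A549 cells (Homo sapiens) for cytotoxicity, read by MTT assay, with a stated time of 72 h (on this read-out higher numbers stand for weaker inhibition and lower numbers for stronger inhibition), compound 1 gives "not active" (no number reported)
compound 2 `COc1cc(/C=C/C(=O)Nc2cc3c(Nc4ccc(F)c(Cl)c4)ncnc3cc2O[C@H]2CCOC2)cc(OC)c1` — compound 2 gives 10800 nM
compound 3 `COc1cc2ncnc(Nc3ccc(F)c(Cl)c3)c2cc1NC(=O)/C=C/c1cc(OC)c(OC)c(OC)c1` — compound 3 gives "not active" (no number reported)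

Among the compounds with values here, compound 2 is the only member of the series with a number in this assay; compound 1 and compound 3 are recorded only as not active, without a number, so no comparison between measured compounds can be drawn and no step is available. Where compound 2 stands on the numbers shown is therefore simply this: it holds the single value in the set.

Compound 4 `N#Cc1ccc(/C=C/C(=O)Nc2cc3c(Nc4ccc(F)c(Cl)c4)ncnc3cc2O[C@H]2CCOC2)cc1` is still to be measured in this assay. It differs from compound 2 in one place: 4-cyanophenyl in place of 3,5-dimethoxyphenyl on a double-bonded chain carbon bound to a double-bonded chain carbon. Within the data shown here, nothing among the measured compounds bears on what 4-cyanophenyl in place of 3,5-dimethoxyphenyl does here, so the step is expected to be a 1.1-fold lower number from compound 2 to compound 4 (0.03 log units; within the scatter), that is, none beyond the scatter. Compound 4 is accordingly expected to give about 10000 nM in this assay, with a range from 3000 nM to 40000 nM.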

Compound 4, half-maximal inhibitory concentration: "not active" (no number reported)
For compound 4 the study gives words and no number; there is nothing to compare the estimate with.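

No new step can be read: in this assay compound 2 gives 10800 nM while compound 4 carries words and no number. No evidence shown bears on this result. The compounds shown leave open what 4-cyanophenyl in place of 3,5-dimethoxyphenyl does to the number.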